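Halogen loss and amine methylation on a sulfonamide chain

A few compounds are considered here, and "the series" means these few. Any claim that something is new, unique, unknown or untested is made for them only; others in the source may bear on it.

Measured so far in a functional assay on Capan-2 cells (Homo sapiens) for inhibition, read by MTT assay, with a stated time of 72 h; a lower number here means a stronger inhibitor of growth, a higher number a weaker inhibitor of growth:
compound 1 `O=S(=O)(NCCCNCc1ccccc1Cl)c1cc(C(F)(F)F)cc(C(F)(F)F)c1` gives 13000 nM
compound 2 `O=S(=O)(NCCCCNCc1ccc(Br)cc1)c1cc(C(F)(F)F)cc(C(F)(F)F)c1` gives 1900 nM
compound 3 `O=S(=O)(NCCCNCc1ccc(Cl)c(Cl)c1)c1cc(C(F)(F)F)cc(C(F)(F)F)c1` gives 1800 nM

Compound 3 has the lowest number of the three in this assay, though its gap to compound 2 is within the scatter; only compound 1 stands clearly apart, as seen in a 7.2-fold lower number from compound 1 to compound 3 (0.86 log units; beyond the scatter) and in a 6.8-fold lower number from compound 1 to compound 2 (0.84 log units; beyond the scatter). Compound 4 `CN(CCCNS(=O)(=O)c1cc(C(F)(F)F)cc(C(F)(F)F)c1)Cc1ccccc1` differs from compound 3 in one place: benzyl(methyl)amino in place of (3,4-dichlorobenzyl)amino on a saturated chain carbon, three bonds along the chain from a sulfonamide nitrogen. Within the data shown here, no measured step removes every halogen from the benzyl group or replaces the amine hydrogen with a methyl, so the change is only loosely covered. What the data do show is that the arrangement of halogens matters: between compound 1 and compound 3 the step was modest but beyond the scatter, while compound 2 and compound 3 sit together, as a 1.1-fold lower number from compound 2 to compound 3 (0.02 log units; within the scatter) shows. Removing the halogens altogether is therefore expected to raise the number in this assay, likely by a step of the size seen across the measured compounds, a 4.4-fold higher number from compound 3 to compound 4 (0.65 log units; beyond the scatter). Compound 4 is estimated at 8000 nM, in the range 3000 nM to 25000 nM.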

Compound 4, concentration for 50% growth inhibition: 46000 nM
The estimate for compound 4 lay 5.8-fold (0.76 log units) below the measured number; the measured number lies above the stated range.
By their numbers in this assay, from the lowest: compounds 3 and 2 (each within the scatter of the next); then compound 1; then compound 4.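

In this assay the change on a saturated chain carbon, three bonds along the chain from a sulfonamide nitrogen, turns out to be large, with a 26-fold higher number from compound 3 to compound 4 (1.41 log units; beyond the scatter) and a 24-fold higher number from compound 2 to compound 4 (1.38 log units; beyond the scatter) as its measure. Compound 4 also stands clear of compound 1, which until now had the highest number, as a 3.5-fold higher number from compound 1 to compound 4 (0.55 log units; beyond the scatter) shows, so a benzyl group free of halogen with a methyl on the amine nitrogen gives the highest number of the four. No measurement offered here accounts for this result.

The halogens leave and the methyl enters in the same step, so the compounds shown do not tell the two changes apart. A plain benzylamino group, or a 3,4-dichlorobenzyl group with a methyl on its amine nitrogen, would divide that step.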